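The source may hold more compounds than are shown below. What is called first, only, known or untested is meant among the compounds shown, and "the series" means these compounds.

Compound 1 `COc1ccc(Cl)cc1S(=O)(=O)Nc1cncc(-c2cccnc2)c1` gives 73 nM in an assay on isolated protein for inhibition of alkaline phosphatase, tissue-nonspecific isozyme (Homo sapiens); a higher number here means a weaker inhibitor, a lower number a stronger inhibitor. Compound 2 `CNC(=O)c1cncc(NS(=O)(=O)c2cc(Cl)ccc2OC)c1` gives 109 nM in this assay, and the step of a 1.5-fold higher number from compound 1 to compound 2 (0.17 log units; within the scatter) places the two within the scatter of each other, so neither stands apart. Compound 3 `COc1ccc(Cl)cc1S(=O)(=O)Nc1cncc(C(=O)Nc2ccccc2)c1` differs from compound 2 by phenyl in place of methyl on an amide-type nitrogen. No measured step touches this amide-type nitrogen, so no shown comparison bears on the change; the expectation is a step of a 1.1-fold lower number from compound 2 to compound 3 (0.04 log units; within the scatter) that stays within the scatter. Compound 3 is therefore expected to give about 100 nM in this assay, between 35 nM and 300 nM.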

Compound 3, half-maximal inhibitory concentration: 310 nM
Estimate against measurement, compound 3: 3.1-fold (0.49 log units) below; the whole stated range lies below it.
By their numbers in this assay, from the lowest: compounds 1 and 2 (each within the scatter of the next); then compound 3.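

In this assay the group on the amide-type nitrogen matters: phenyl in place of methyl brings a 2.8-fold higher number from compound 2 to compound 3 (0.45 log units; beyond the scatter) and so moves the number beyond the scatter, though only modestly. Set against the pyridin-3-yl group, the phenylcarbamoyl group brings a 4.2-fold higher number from compound 1 to compound 3 (0.63 log units; beyond the scatter) as well, whereas the methylcarbamoyl group stayed within the scatter. No measurement at hand explains this rise. Still open, from the compounds shown here alone, is how other groups on this nitrogen, such as ethyl, cyclohexyl or benzyl, would compare with methyl and phenyl.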